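Swapping the urea-side aryl group toward compound 4

The source may report more compounds than this note shows. Statements on the series, on what has been measured and on what is new or still open speak of the compounds shown alone.

Measured compounds:
compound 1 `O=C(Nc1cccc(Cl)c1)N[C@H]1CC[C@H](Oc2ccc(F)cc2)CC1`: 5900 nM
compound 2 `O=C(Nc1cccc(C(F)(F)F)c1)N[C@H]1CC[C@H](Oc2ccccc2F)CC1`: 2450 nM
compound 3 `O=C(Nc1cccc(C(F)(F)F)c1)N[C@H]1CC[C@H](Oc2ccc(C(F)(F)F)cc2)CC1`: 460 nM

In a functional assay on CRL2813 cells (Homo sapiens) for cytotoxicity, read by sulforhodamine B assay, with a stated time of 5 days (on this read-out lower numbers stand for stronger inhibition and higher numbers for weaker inhibition), compound 1 stands highest of the three numbers; compound 2 gives 2450 nM and compound 3 gives 460 nM. Compound 4 `CSc1ccc(NC(=O)N[C@H]2CC[C@H](Oc3ccc(F)cc3)CC2)cc1` is not yet measured. It differs from compound 1 by 4-(methylsulfanyl)phenyl in place of 3-chlorophenyl on an amide-type nitrogen. Among the measured compounds shown here, the only measured step, a 5.3-fold lower number from compound 2 to compound 3 (0.73 log units; beyond the scatter), changes the group on the oxygen, not the group on the amide-type nitrogen, so no measured step bears directly on this change. Compounds 1 and 2 differ in two places at once, so their gap cannot be assigned to either. With no direct guide, the expected step for compound 4 is small, a 1.2-fold lower number from compound 1 to compound 4 (0.07 log units; within the scatter), in either direction. Compound 4 is therefore estimated at 5000 nM, within 1500 nM to 16000 nM.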

Compound 4, half-maximal inhibitory concentration: > 20000 nM
Compound 4 ended at the assay's limit (the forecaster's own chance of this, stated with the estimate: 5%); at least 4.0-fold (0.60 log units) between middle value and limit.
By their numbers in this assay, from the lowest: compound 3; then compound 2; then compound 1. At a limit, above all of these: compound 4.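

Among the compounds shown here, putting 4-(methylsulfanyl)phenyl in place of 3-chlorophenyl on an amide-type nitrogen gives an at least 3.3-fold higher number from compound 1 to compound 4 (0.53 log units; beyond the scatter) in this assay, so this place, which no earlier step could speak to, clearly affects the read-out. Compound 4 gives > 20000 nM, which is a limit of the assay and not a number, so the full size of the step stays unknown: the limit of > 20000 nM in this assay, at which 1 of the 4 values shown sits.

Whether the sulfur-bearing group itself or its different place on the ring accounts for the step stays open. So does how a phenyl carrying an amine or a carboxylic acid would read on this nitrogen.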